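Thiophene swap on a four-membered ring in MCF7 antiproliferation

The compounds below may be only part of what the source reports. "The series", "measured", "known", "first", "only" and "open" are said of these compounds alone.

Measured in a functional assay on MCF7 cells (Homo sapiens) for antiproliferative activity, read by MTT assay; a higher number here means a weaker inhibitor, a lower number a stronger inhibitor:
compound 1 `COc1ccc([C@@H]2[C@@H](C(O)c3cccs3)C(=O)N2c2cc(OC)c(OC)c(OC)c2)cc1`: 1200 nM
compound 2 `COc1ccc([C@@H]2/C(=C/c3cccs3)C(=O)N2c2cc(OC)c(OC)c(OC)c2)cc1`: 4050 nM
compound 3 `COc1ccc([C@@H]2C(c3ccc(C)s3)C(=O)N2c2cc(OC)c(OC)c(OC)c2)cc1`: 250 nM

Compound 3 has the lowest number of the three. The numbers for compound 1 and compound 2 both lie above it, and both gaps are beyond the scatter of repeated measurements. No two of these compounds differ in one place only, so the series offers no measured single change to lean on.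

The next compound, compound 4 `COc1ccc([C@@H]2C(c3ccsc3)C(=O)N2c2cc(OC)c(OC)c(OC)c2)cc1`, has thiophen-3-yl in place of 5-methylthiophen-2-yl on a saturated ring carbon of a four-membered non-aromatic ring with 1 nitrogen (thiophen-3-yl in place of 5-methylthiophen-2-yl on a saturated ring carbon). A five-membered aromatic ring with 1 hetero atom stays at this place, so the expectation starts from compound 3 at 250 nM in this assay. Within the data shown here, with no direct precedent, the direction is a judgement and remains uncertain. A moderate move towards a stronger inhibitor is expected, slightly beyond the scatter. The expected step is a 2.3-fold lower number from compound 3 to compound 4 (0.36 log units; beyond the scatter). For compound 4 the estimated value is 110 nM, with an expected range from 25 nM to 450 nM.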

Compound 4, half-maximal inhibitory concentration: 60 nM
Compound 4: the middle estimate sits 1.8-fold (0.26 log units) above what was measured; the range from low to high includes it.
By their numbers in this assay, from the lowest: compound 4; then compound 3; then compound 1; then compound 2.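

In this assay, among these compounds, the swap gives a 4.2-fold lower number from compound 3 to compound 4 (0.62 log units; beyond the scatter), the first single change, and it shows that the group on this saturated ring carbon of the four-membered ring can shift the number beyond the scatter even when a five-membered aromatic ring with 1 hetero atom stays in place. The leaving and entering groups have the same ring type, the same counts of hydrogen-bond donors and acceptors and no net charge, yet the step bundles two differences, the loss of the methyl group and a different point of attachment on the thiophene, and it cannot tell them apart. Nothing measured here accounts for the step.

The compounds shown leave open whether the methyl group or the point of attachment carries the difference, a question that the plain thiophen-2-yl group at this place would address. They also leave open whether the sulfur-containing ring matters at all, since neither a phenyl nor a furan-3-yl group appears here, and how far this change would hold on other versions of the shared core.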